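A single measured value and one exchanged group

The source may hold more compounds than are shown below. What is called first, only, known or untested is meant among the compounds shown, and "the series" means these compounds.

Among these related amides, compound 1 `Nc1nc2c(s1)CCC[C@H]2C(=O)Nc1ccc(C[C@@H]2CC[C@H]([C@H](O)c3ccccc3)N2)cc1` is the only one with a number. In an ADME assay on the whole organism (plasma, Rattus norvegicus, strain Sprague-Dawley) for protein binding (on this read-out higher numbers stand for a larger free fraction and lower numbers for a smaller free fraction), compound 1 gives 0.14 as its reading. Compound 2 `Nc1nc2c(s1)CC[C@H]2C(=O)Nc1ccc(C[C@@H]2CC[C@H]([C@H](O)c3cccnc3)N2)cc1` has no result reported, so compound 1 cannot be ranked against anything, and it is neither high nor low within this set. Compound 3 `O=C(Nc1ccc(C[C@@H]2CC[C@H]([C@H](O)c3ccccc3)N2)cc1)[C@@H]1CCc2scnc21` has not yet been measured. It keeps the amide-type nitrogen and everything beyond it, and the change lies in the group on the carbonyl carbon: a group of 8 heavy atoms (6 carbon, 1 nitrogen, 1 sulfur; one five-membered non-aromatic ring of carbon only, one five-membered aromatic ring with 2 hetero atoms) in place of a group of 10 heavy atoms (7 carbon, 2 nitrogen, 1 sulfur; one five-membered aromatic ring with 2 hetero atoms, one six-membered non-aromatic ring of carbon only), on a carbonyl carbon is the whole of the difference from compound 1.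

Among the compounds with values here, no measured pair shows what an exchange of this kind does in this assay and the data offer no trend to extend. The expectation therefore rests on compound 1 at 0.14 alone, and no shift beyond the scatter is expected in either direction. The expected step of a 1.1-fold lower number from compound 1 to compound 3 (0.03 log units; within the scatter) is small and stays within that scatter. Compound 3 is estimated at 0.13 with an expected range from 0.07 to 0.25 in this measurement.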

Compound 3, unbound fraction: 0.1
For compound 3 the middle estimate is 1.3-fold (0.11 log units) above the measured one, within the range that was stated.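

In this assay, within the data shown here, the exchange on a carbonyl carbon, a group of 8 heavy atoms in place of a group of 10 heavy atoms, gives a 1.4-fold lower number from compound 1 to compound 3 (0.15 log units; within the scatter) and so provides the first measured pair in this set; the step stays within the scatter, and the two readings cannot be told apart. At this position, then, going from a group with 1 hydrogen-bond donor and 3 hydrogen-bond acceptors to one with 0 hydrogen-bond donors and 2 hydrogen-bond acceptors, and from a six-membered to a five-membered non-aromatic ring of carbon only, leaves the free fraction indistinguishable on this single comparison. Nothing measured here offers an explanation for the size of this step.

Because all of these features change together in one exchange, the pair cannot show what any one of them contributes on its own. From the compounds shown here alone, whether the reading would also hold with a carboxylic acid or an open butyl chain on the carbonyl carbon remains open, and compound 2, with no result reported, adds no comparison.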